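The source may report more compounds than this note shows. Statements on the series, on what has been measured and on what is new or still open speak of the compounds shown alone.

Measured in a functional assay on CHO cells for agonist activity at metabotropic glutamate receptor 2 (Homo sapiens), read by scintillation counting and GTPgammaS binding, with a stated time of 30 min; on this read-out lower numbers stand for an effect already at smaller amounts and higher numbers for an effect only at larger amounts of compound:
compound 1, `COc1cccc(F)c1C1CCN(c2ccn3c(CC4CC4)nnc3c2Cl)CC1`, gives 6 nM
compound 2, `COc1ccc(F)c(F)c1C1CCN(c2ccn3c(CC4CC4)nnc3c2Cl)CC1`, gives 9.3 nM
compound 3, `COc1c(F)cccc1C1CCN(c2ccn3c(CC4CC4)nnc3c2C(F)(F)F)CC1`, gives 11 nM

Compound 2 differs from compound 1 by fluoro in place of hydrogen on an aromatic carbon, and that step gave a 1.6-fold higher number from compound 1 to compound 2 (0.19 log units; within the scatter). Compound 3 carries another core; the difference between the two cores is not broken down here. Compound 4, `COc1c(F)ccc(F)c1C1CCN(c2ccn3c(CC4CC4)nnc3c2C(F)(F)F)CC1`, is not yet measured and differs from compound 3 by fluoro in place of hydrogen on an aromatic carbon. This is the same kind of change as from compound 1 to compound 2, not the same: in compound 2 the entering fluoro sits ortho to a fluoro group, meta to a large group and para to a methoxy group, whereas in compound 4 it sits ortho to a large group, meta to a methoxy group and para to a fluoro group. The expected step is a 1.4-fold higher number from compound 3 to compound 4 (0.13 log units; within the scatter), resting on the earlier step being within the scatter. Compound 4 is therefore expected to give about 15 nM in this assay, with a likely range of 6 nM to 40 nM.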

Compound 4, half-maximal effective concentration: 4.1 nM
The estimate for compound 4 lay 3.7-fold (0.56 log units) above the measured number, and the stated range ends above it.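

Fluoro in place of hydrogen gives a 2.7-fold lower number from compound 3 to compound 4 (0.43 log units; beyond the scatter) in this assay and does not carry over as one fixed step between the two cores: the same change on two cores in this assay, a 1.6-fold higher number (0.19 log units; within the scatter) from compound 1 to compound 2 and a 2.7-fold lower number (0.43 log units; beyond the scatter) from compound 3 to compound 4, 4.2-fold (0.62 log units) apart, beyond the scatter of two such steps

The two steps differ in the core and also in where the entering fluoro sits on the ring, so this pair cannot show which of the two sets them apart. With one pair on each core, no rule for any further core follows.

Open, on these data alone, is how the 3,6-difluoro-2-methoxyphenyl group behaves on the core of compound 1. Also open, as far as these compounds go, is what happens when an ethoxy group or a nitrile replaces the methoxy group, or an amine or a longer chain replaces the cyclopropylmethyl group.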